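Series notes: aryloxy hydrazone, chloro to methyl

The source may report more compounds than this note shows. Statements on the series, on what has been measured and on what is new or still open speak of the compounds shown alone.

Compound 3, `Clc1ccc(Oc2ccc(/C=N/Nc3nc4ccccc4s3)cc2)cc1`, gives 5.6 in a physicochemical assay for lipophilicity, in phosphate buffer, measured as octanol-water partition, with a stated time of 24 h (a higher number here means a more lipophilic compound, a lower number a more polar compound), and stands highest of the three measured numbers. Compound 1, `Fc1ccc(Oc2ccc(/C=N/Nc3nc4ccccc4s3)cc2)cc1`, gives 5; compound 2, `C(=N/Nc1nc2ccccc2s1)\c1ccc(Oc2ccccc2)cc1`, gives 5.2. The steps run a number 0.20 log units higher from compound 1 to compound 2 (within the scatter), a number 0.60 log units higher from compound 1 to compound 3 (beyond the scatter) and a number 0.40 log units higher from compound 2 to compound 3 (beyond the scatter). Compound 4, `Cc1ccc(Oc2ccc(/C=N/Nc3nc4ccccc4s3)cc2)cc1`, differs from compound 3 by methyl in place of chloro on an aromatic carbon. Going by the values given here, no measured step exchanges a methyl group, so the step from compound 2 to compound 3 is the nearest guide: it puts the chloro group a modest distance above hydrogen at this position, and the methyl group is taken to sit at a similar height or slightly lower. For compound 4 a small step, within the scatter, is therefore expected in this assay, a number 0.10 log units lower from compound 3 to compound 4 (within the scatter), with the direction uncertain. Compound 4 is estimated at 5.5, with a range from 5.2 to 5.8.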

Compound 4, partition coefficient: 5.4
Compound 4: middle estimate off by 0.10 log units, on the high side; the range from low to high includes it.
By their numbers in this assay, from the lowest: compounds 1, 2, 4 and 3 (each within the scatter of the next, the first and the last beyond it).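

At this position, on an aromatic carbon para to a large group, methyl in place of chloro gives a number 0.20 log units lower from compound 3 to compound 4 (within the scatter) in this assay and does not separate the two groups. Methyl in place of hydrogen gives a number 0.20 log units higher from compound 2 to compound 4 (within the scatter) and so stays within the scatter of the unsubstituted compound, whereas chloro in place of hydrogen gives a number 0.40 log units higher from compound 2 to compound 3 (beyond the scatter) and does not. Methyl in place of fluoro gives a number 0.40 log units higher from compound 1 to compound 4 (beyond the scatter) and is the only step from the new compound that clears the scatter, so methyl is told apart from fluoro but from neither hydrogen nor chloro.

From the compounds shown here alone, whether an amine, a methoxy group or a carboxylic acid at this position would stay close to these four numbers remains open. Nothing available here gives a reason for any of these steps.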